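This account rests on a few compounds, and the source may have more. Where it says the series, first, only, none or still open, it means among the compounds named here.

Among the compounds with values here, in a functional assay on MOLT-4 cells (Homo sapiens) for inhibition (on this read-out lower numbers stand for stronger inhibition and higher numbers for weaker inhibition), compound 1 `O=C1O/C(=C\Cn2cc(C(F)(F)F)c(=O)[nH]c2=O)C(OCc2ccccc2)=C1OCc1ccccc1` gives 900 nM, the lower of the two numbers measured so far, while compound 2 `O=C1O/C(=C\Cn2cc(I)c(=O)[nH]c2=O)C(OCc2ccccc2)=C1OCc1ccccc1` gives 3900 nM. Compound 3 `O=C1O/C(=C\Cn2cc(Br)c(=O)[nH]c2=O)C(OCc2ccccc2)=C1OCc1ccccc1` has not yet been measured. Its structure departs from compound 1 as follows: bromo in place of trifluoromethyl on an aromatic carbon. Within the data shown here, one measured step bears on this change, a 4.3-fold higher number from compound 1 to compound 2 (0.64 log units; beyond the scatter), where iodo takes the place of trifluoromethyl on that same carbon. This step is modest but beyond the scatter. Among the measured compounds shown here, no measured compound yet carries bromo, so this single step is the only guide, and a modest rise of similar direction is expected in this assay. The expected change is a 2.9-fold higher number from compound 1 to compound 3 (0.46 log units; beyond the scatter). For compound 3 the estimated value is 2600 nM, with an expected range of 1000 nM to 7000 nM.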

Compound 3, half-maximal inhibitory concentration: 3900 nM
Compound 3: the middle estimate sits 1.5-fold (0.18 log units) below what was measured; the range from low to high includes it.
By their numbers in this assay, from the lowest: compound 1; then compounds 2 and 3 (each within the scatter of the next).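

In this assay, bromo on this aromatic carbon gives a 4.3-fold higher number from compound 1 to compound 3 (0.64 log units; beyond the scatter), which shows that the weaker inhibition seen with iodo is not confined to iodo. Bromo in place of iodo gives no change at the digits printed from compound 2 to compound 3 (within the scatter), so this read-out does not separate these two halogens at this position, while compound 1, with trifluoromethyl, keeps the lowest number of the three. Nothing available explains this difference between trifluoromethyl and the two halogens.

The compounds shown leave open whether chloro, fluoro, a methyl group or a nitrile on the same carbon would fall with compound 1 or with compounds 2 and 3. They also leave open whether a plain hydrogen there would match either level, and whether the same order would hold with other groups on the shared core.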